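Cyano for Nitro on the Benzyl Group of Compound 3

The source may hold more compounds than are shown below. What is called first, only, known or untested is meant among the compounds shown, and "the series" means these compounds.

Compound 1 `C=CCn1c(=O)n(C2OC(CO[Si](c3ccccc3)(c3ccccc3)C(C)(C)C)[C@@H](O)[C@H]2O)c2nc(N)nc(O)c21`: 33%
Compound 2 `C=CCn1c(=O)n(C2OC(CO[Si](C)(C)C(C)(C)C)[C@@H](O)[C@H]2O)c2nc(N)nc(O)c21`: 5%
Compound 3 `Nc1nc(O)c2c(n1)n(C1OC(CO)[C@@H](O)[C@H]1O)c(=O)n2Cc1ccc([N+](=O)[O-])cc1`: 147%

In a functional assay on the whole organism (B cells) with Mus musculus as the target (on this read-out higher numbers stand for larger maximal responses and lower numbers for smaller maximal responses), compound 3 gives the highest of the three numbers; compound 1 is the nearest to it and compound 2 the furthest, and both gaps lie beyond the scatter. Compound 4 `N#Cc1ccc(Cn2c(=O)n(C3OC(CO)[C@@H](O)[C@H]3O)c3nc(N)nc(O)c32)cc1` differs from compound 3 by cyano in place of nitro on an aromatic carbon, a change from 4-nitrobenzyl to 4-cyanobenzyl. Among the compounds with values here, no pair of measured compounds shows this change, so its size in this assay cannot be read from the data. A modest decrease is expected, one that may not exceed the scatter, and the expected step of a number 27 percentage points lower from compound 3 to compound 4 (beyond the scatter) is taken as downward. Compound 4 is therefore estimated to give 120%, with a range from 70% to 170%.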

Compound 4, largest response reached (reported as maximal response), in percent of the reference or control that the assay uses: 50%
For compound 4 the middle estimate is 70 percentage points above the measured one; measured number below the stated range.
By their numbers in this assay, from the lowest: compound 2; then compound 1; then compound 4; then compound 3.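

In this assay, within the data shown here, cyano in place of nitro on the aromatic carbon gives a number 97 percentage points lower from compound 3 to compound 4 (beyond the scatter) as the only step between compounds that differ in one place. This shows that the response is sensitive to the group at this place, and that exchanging 4-nitrobenzyl for 4-cyanobenzyl is far from a neutral swap. Nothing given here explains the size of this step. As far as these compounds go, how an amine, a carboxylic acid or a plain hydrogen at this carbon would compare remains open, as does whether the same change would have a similar effect on a different core.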